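A few compounds are considered here, and "the series" means these few. Any claim that something is new, unique, unknown or untested is made for them only; others in the source may bear on it.

In a functional assay on NCI-H460 cells (Homo sapiens) for cytotoxicity, read by MTT assay, with a stated time of 72 h (a lower number here means a stronger inhibitor, a higher number a weaker inhibitor), compound 3 (`CCN(CC)Cc1ccc2nc(NC(=O)N/N=C/c3cn(Cc4ccc(Cl)cc4Cl)c4ccccc34)sc2c1`) gives 1080 nM, within the scatter of compound 1 (`CCN(CC)Cc1ccc2nc(NC(=O)N/N=C/c3cn(Cc4ccc(C(C)(C)C)cc4)c4ccccc34)sc2c1`) at 1670 nM, while compound 2 (`CC1CCN(Cc2ccc3nc(NC(=O)N/N=C/c4cn(Cc5cccc(Cl)c5)c5ccccc45)sc3c2)CC1`) lies clearly lower at 280 nM. The move to compound 4 (`CCN(CC)Cc1ccc2nc(NC(=O)N/N=C/c3cn(Cc4cccc(Cl)c4)c4ccccc34)sc2c1`) is 3-chlorophenyl in place of 2,4-dichlorophenyl on a saturated chain carbon bound to an aromatic nitrogen, with 3-chlorophenyl in place of 2,4-dichlorophenyl on a saturated chain carbon bound to an aromatic nitrogen. Going by the values given here, the only measured step at this place, a 1.5-fold lower number from compound 1 to compound 3 (0.19 log units; within the scatter), is small. Compound 2 carries the same 3-chlorophenyl group but also differs from compound 4 elsewhere, so it offers only a weak hint toward a lower number. The step expected in this assay is modest and downward: a 1.8-fold lower number from compound 3 to compound 4 (0.26 log units; within the scatter). Compound 4 is estimated at 600 nM, with an expected range of 240 nM to 1400 nM.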

Compound 4, half-maximal inhibitory concentration: 220 nM
Estimate against measurement, compound 4: 2.7-fold (0.44 log units) above; measured number below the stated range.
By their numbers in this assay, from the lowest: compounds 4 and 2 (each within the scatter of the next); then compounds 3 and 1 (each within the scatter of the next).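

At this place, on a saturated chain carbon bound to an aromatic nitrogen, the aryl group now matters in this assay: 3-chlorophenyl brings a 4.9-fold lower number from compound 3 to compound 4 (0.69 log units; beyond the scatter) and a 7.6-fold lower number from compound 1 to compound 4 (0.88 log units; beyond the scatter) in the two steps that show it, whereas a 1.5-fold lower number from compound 1 to compound 3 (0.19 log units; within the scatter) had suggested little effect. With 3-chlorophenyl in place, the amine change shows only a 1.3-fold lower number from compound 2 to compound 4 (0.10 log units; within the scatter) for diethylamino against 4-methylpiperidin-1-yl. No measurement shown bears on the reason for these steps. Unsubstituted phenyl and a methoxy group in place of the chlorine remain open at this place. From the compounds shown here alone, whether the amine change stays this small with other aryl groups also remains open.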